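Thiosemicarbazide amidrazones: pyrrolidine to morpholine on the thiocarbonyl

The source may report more compounds than this note shows. Statements on the series, on what has been measured and on what is new or still open speak of the compounds shown alone.

Compound 1 `N/C(=N\NC(=S)N1CCCC1)c1ccc(F)cn1` in a functional assay on A-431 cells (Homo sapiens) for cytotoxicity, read by MTT assay, with a stated time of 72 h, tested at 30 uM (on this read-out lower numbers stand for less inhibition of growth and higher numbers for more inhibition of growth at the one concentration tested), gives 83.3%. Compound 2 `N/C(=N\NC(=S)N1CCCCC1)c1ccccn1` in this assay gives 79.7%, and the two numbers lie within the scatter of each other, so compound 1 cannot be set apart from compound 2 on these data. Compound 3 `N/C(=N\NC(=S)N1CCOCC1)c1ccc(F)cn1` differs from compound 1 by morpholin-4-yl in place of pyrrolidin-1-yl on a thiocarbonyl carbon. Going by the values given here, no measured pair shows this change, so the size of the step is open; a small shift, if any, is expected, not beyond the scatter, with the step from compound 1 to compound 3 estimated as a number 8.3 percentage points lower from compound 1 to compound 3 (within the scatter). Compound 3 is therefore expected at 75%, within 55% to 92%.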

Compound 3, percent growth inhibition at one concentration: 82.3%
Estimate against measurement, compound 3: 7.3 percentage points below; the measured number falls inside the stated range.
By their numbers in this assay, from the lowest: compounds 2, 3 and 1 (each within the scatter of the next).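

Morpholin-4-yl in place of pyrrolidin-1-yl on the thiocarbonyl carbon gives, in this assay, a number 1 percentage points lower from compound 1 to compound 3 (within the scatter), the first step measured at this position. The added ring oxygen and the six-membered ring therefore leave the read-out within the scatter on the core of compound 1. No available evidence explains this result.

As far as these compounds go, whether an open-chain dimethylamino group or a piperazin-1-yl ring on the thiocarbonyl carbon would stay within the scatter remains open. Single-concentration values also leave relative potency open.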